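The source may report more compounds than this note shows. Statements on the series, on what has been measured and on what is new or still open speak of the compounds shown alone.

In a functional assay on LNCaP cells (Homo sapiens) for antiproliferative activity, read by sulforhodamine B assay, with a stated time of 96 h (a lower number here means a stronger inhibitor, a higher number a weaker inhibitor), three compounds sharing one core have been measured. Compound 1 (`CN(C)c1ccc2c(c1)OC(N)=C(C#N)C2c1cccc2c(F)cccc12`) gives 250 nM and compound 2 (`CN(C)c1ccc2c(c1)OC(N)=C(C#N)C2c1cccc2c(Br)cccc12`) gives 280 nM. Compound 3 (`COc1ccc(C2C(C#N)=C(N)Oc3cc(N(C)C)ccc32)c2ccccc12`) gives 760 nM, the highest of the three numbers, and its gap to each of the other two lies beyond the scatter.

Compound 4 (`CN(C)c1ccc2c(c1)OC(N)=C(C#N)C2c1ccc(F)c2ccccc12`) has not yet been measured. It differs from compound 3 by fluoro in place of methoxy on an aromatic carbon, para to a large group: fluoro in place of methoxy on an aromatic carbon. Among the measured compounds shown here, no measured step makes this exchange directly. For the measured compounds named here, the only step available is a 1.1-fold higher number from compound 1 to compound 2 (0.05 log units; within the scatter), bromo in place of fluoro, and it stays within the scatter. It suggests that these two groups are not told apart at the place they occupy in those compounds, which is not the place of the fluoro in compound 4, so it bears on the new step only loosely. Compound 1, also a fluoro compound, gives 250 nM, so compound 4 is expected to fall nearer that number than the number of compound 3. The expected change is a 2.2-fold lower number from compound 3 to compound 4 (0.34 log units; beyond the scatter), towards a lower number. For compound 4 the estimated value is 350 nM, with an expected range from 130 nM to 900 nM.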

Compound 4, half-maximal inhibitory concentration: 410 nM
Estimate against measurement, compound 4: 1.2-fold (0.07 log units) below, and the stated range covers the measured number.
By their numbers in this assay, from the lowest: compounds 1, 2, 4 and 3 (each within the scatter of the next, the first and the last beyond it).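

Among the compounds shown here, replacing methoxy by fluoro on an aromatic carbon, para to a large group, is the first exchange that can be read directly at this position, and in this assay it amounts to a 1.9-fold lower number from compound 3 to compound 4 (0.27 log units; within the scatter). At this place, then, the read-out does not tell apart the methoxy, which carries a hydrogen-bond acceptor, from the fluoro, which carries none, so the result gives no grounds for treating either group as the better one here. Nothing available explains why the two groups are not told apart.

This single exchange cannot show whether the position accepts groups of other kinds, and an amine, a carboxylic acid or a longer chain such as butoxy at the same aromatic carbon could give a different answer from the one seen with methoxy and fluoro. As far as these compounds go, it also remains open how a plain hydrogen at this place would compare, and whether the same exchange would give a step of similar size in any other cell line or on a core carrying a different group in place of the dimethylamino group.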